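A few compounds are considered here, and "the series" means these few. Any claim that something is new, unique, unknown or untested is made for them only; others in the source may bear on it.

In an ADME assay on CV-1 cells (Chlorocebus aethiops) for cytotoxicity (on this read-out lower numbers stand for higher toxicity in this test and higher numbers for lower toxicity in this test), compound 1 (`Nc1nc(F)cc2c1ncn2[C@@H]1C=C(CO)[C@@H](O)[C@H]1O`) gives only a limit, > 100000 nM. Compound 2 (`Nc1nc(F)cc2c1ncn2[C@@H]1C[C@H](CO)[C@@H](O)[C@H]1O`) likewise gives only a limit, > 355000 nM. Neither result is an exact number, so the two compounds cannot be placed in order. Compound 3 (`Nc1nc(F)cc2c1ncn2[C@@H]1C[C@H](CCO)[C@@H](O)[C@H]1O`) has not yet been measured. It differs from compound 2 on a saturated chain carbon bound to a saturated ring carbon, where hydroxy gives way to hydroxymethyl, so that hydroxymethyl becomes 2-hydroxyethyl: hydroxymethyl in place of hydroxy on a saturated chain carbon bound to a saturated ring carbon. Going by the values given here, no measured pair of compounds shows what this change does in this assay, so no step beyond the usual scatter is expected, in either direction. The expectation starts from compound 2, whose limit is > 355000 nM. The estimated change is small, an at least 1.1-fold lower number from compound 2 to compound 3 (0.07 log units; that floor lies within the scatter). For compound 3 the expected value is 300000 nM, with an estimated range from 100000 nM to 600000 nM.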

Compound 3, half-maximal cytotoxic concentration: > 338000 nM
Compound 3: only a limit was reported (the forecaster's own chance of this, stated with the estimate: 80%); middle value at least 1.1-fold (0.05 log units) away from the limit.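

Going by these compounds alone, compound 2 and compound 3 each give only a limit in this assay, so no step between them can be read. The compounds shown leave open whether hydroxymethyl in place of hydroxy changes this read-out at all, and at what concentration any of them would harm the cells.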